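A few compounds are considered here, and "the series" means these few. Any claim that something is new, unique, unknown or untested is made for them only; others in the source may bear on it.

Of the compounds shown here, two so far carry values in a functional assay for inhibition, with Homo sapiens as the target; on this read-out lower numbers stand for stronger inhibition and higher numbers for weaker inhibition. Compound 1 `COCc1ncc2cnnc(SC)n12` reaches only the limit of the assay, giving > 48000 nM. Compound 2 `CNc1nncc2cncn12` likewise shows no more than a limit, > 48000 nM. Compound 2 thus stands at the floor of what this assay reports: the limit of > 48000 nM in this assay, at which 2 of the 2 values shown sit. Among the measured compounds shown here, no measured step between two compounds exists to guide the next change. Compound 3 `c1nc(Nc2nncc3cncn23)n[nH]1` differs from compound 2 in one place: 1H-1,2,4-triazol-3-yl in place of methyl on a nitrogen on an aromatic ring. For the measured compounds named here, with no measured step to lean on, the expectation is that compound 3 stays close to where compound 2 sits, and the step expected in this assay is a step that the limit leaves unreadable from compound 2 to compound 3, nothing beyond the scatter in either direction. Compound 3 is therefore estimated at 60000 nM in this assay, with a range from 15000 nM to 250000 nM, most likely once more a limit rather than a number.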

Compound 3, half-maximal inhibitory concentration: 46000 nM
Compound 3: the middle estimate sits 1.3-fold (0.12 log units) above what was measured; the measured number falls inside the stated range.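

In this assay compound 3 is the only one of the three shown that gives a number and not a limit, so a group of five heavy atoms with a ring is tolerated on a nitrogen on an aromatic ring without taking the read-out out of the assay's range. The exchange of methyl for 1H-1,2,4-triazol-3-yl amounts to an at least 1.0-fold lower number from compound 2 to compound 3 (0.01 log units; that floor lies within the scatter), so it does not show that this change alters inhibition at all. The step can be read only as a floor because compound 2 stands at a limit: the limit of > 48000 nM in this assay, at which 2 of the 3 values shown sit.

On these data alone, the true distance between compound 2 and compound 3 remains unknown. Also open, as far as these compounds go, is whether a phenyl ring or a plain amine on this nitrogen would give a number in this assay, and how that number would compare with the one for the triazole.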